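Swapping the group on the carbonyl carbon of compound 3

The source may hold more compounds than are shown below. What is called first, only, known or untested is meant among the compounds shown, and "the series" means these compounds.

Of the compounds shown here, three sharing one core have been tested in a functional assay on isolated protein for inhibition of Glucose-dependent insulinotropic receptor (Homo sapiens), read by HTRF and cAMP accumulation; a higher number here means that more compound is needed for the effect, a lower number that less compound is needed. Compound 1 `Cc1nc(S(C)(=O)=O)ccc1Oc1ncnc(OC2CCN(C(=O)OC(C)C)CC2)c1F` gives 21 nM. Compound 2 `Cc1nc(S(C)(=O)=O)ccc1Oc1ncnc(OC2CCN(C(=O)O[C@H](C)C(F)(F)F)CC2)c1F` gives 9.2 nM, and the step of a 2.3-fold lower number from compound 1 to compound 2 (0.36 log units; beyond the scatter) is modest but beyond the scatter. Compound 3 `Cc1nc(S(C)(=O)=O)ccc1Oc1ncnc(OC2CCN(C(=O)SC3CC3)CC2)c1F` gives 24.9 nM, the highest of the three numbers; against compound 1 the step of a 1.2-fold higher number from compound 1 to compound 3 (0.07 log units; within the scatter) lies within the scatter, while against compound 2 the step of a 2.7-fold higher number from compound 2 to compound 3 (0.43 log units; beyond the scatter) is modest.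

Compound 4 `Cc1nc(S(C)(=O)=O)ccc1Oc1ncnc(OC2CCN(C(=O)c3noc(C(C)C)n3)CC2)c1F` differs from compound 3 on the same carbonyl carbon: a group of 8 heavy atoms (5 carbon, 2 nitrogen, 1 oxygen; one five-membered aromatic ring with 3 hetero atoms) in place of a group of 4 heavy atoms (3 carbon, 1 sulfur; one three-membered non-aromatic ring of carbon only), on a carbonyl carbon. The two steps that touch this carbon, a 1.2-fold higher number from compound 1 to compound 3 (0.07 log units; within the scatter) and a 2.7-fold higher number from compound 2 to compound 3 (0.43 log units; beyond the scatter), were small to modest, so changes here have so far moved this assay little. None of them, however, introduces an aromatic ring at this position, so the expectation for compound 4 rests on loose ground.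

Compound 4 is therefore expected to land near compound 3, with an estimated step of a 1.2-fold lower number from compound 3 to compound 4 (0.10 log units; within the scatter) and a value of about 20 nM, within a range of 6 nM to 70 nM.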

Compound 4, half-maximal effective concentration: 21.2 nM
Compound 4: middle estimate off by 1.1-fold (0.03 log units), on the low side; the range from low to high includes it.
By their numbers in this assay, from the lowest: compound 2; then compounds 1, 4 and 3 (each within the scatter of the next).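

In this assay, the 5-isopropyl-1,2,4-oxadiazol-3-yl group shows that this carbonyl carbon accepts a five-membered aromatic ring, and a ring carbon in place of the oxygen or sulfur of the earlier groups, with no change beyond the scatter: a 1.2-fold lower number from compound 3 to compound 4 (0.07 log units; within the scatter), and a 1.0-fold higher number from compound 1 to compound 4 (0.00 log units; within the scatter). The 1-(trifluoromethyl)ethoxy group of compound 2 remains the only one set apart from the others, with a 2.3-fold higher number from compound 2 to compound 4 (0.36 log units; beyond the scatter). Nothing available explains why these different groups read alike in this assay.

As far as these compounds go, it remains open how a phenyl ring or an amine on this carbonyl carbon would read. From the compounds shown here alone, it is also open whether a 1-(trifluoromethyl)ethyl group in place of the isopropyl on the oxadiazole would give a lower number than compound 4.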